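The source may hold more compounds than are shown below. What is called first, only, known or untested is meant among the compounds shown, and "the series" means these compounds.

Measured compounds:
- compound 1, `Cc1cccc(CN2Cc3c(NC(=O)c4ccccc4)n[nH]c3C2(C)C)c1`; in an assay on Sf21 cells for inhibition of high affinity nerve growth factor receptor (Homo sapiens), read by HTRF, with a stated time of 30 min, in the presence of a further agent that is not named here (on this read-out higher numbers stand for weaker inhibition and lower numbers for stronger inhibition), compound 1 gives 1100 nM 
- compound 2, `COc1cccc(CN2Cc3c(NC(=O)c4ccccc4)n[nH]c3C2(C)C)c1`; in this assay compound 2 gives 1120 nM 
- compound 3, `CC1(C)c2[nH]nc(NC(=O)c3ccccc3)c2CN1Cc1cc(F)cc(F)c1`; in this assay compound 3 gives 190 nM 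

Compound 3 has the lowest number of the three, and its distance from the other two is beyond the scatter: the step of a 5.8-fold lower number from compound 1 to compound 3 (0.76 log units; beyond the scatter) and the step of a 5.9-fold lower number from compound 2 to compound 3 (0.77 log units; beyond the scatter) both run in the same direction and are of the same modest size. Compounds 1 and 2 sit within the scatter of one another, the step of a 1.0-fold higher number from compound 1 to compound 2 (0.01 log units; within the scatter) being too small to read as a change.

Compound 4, `CC1(C)c2[nH]nc(NC(=O)c3ccccc3)c2CN1Cc1cc(F)c(F)c(F)c1`, is not yet measured. It differs from compound 3 by fluoro in place of hydrogen on an aromatic carbon. Within the data shown here, the steps that bear on this are the two that exchanged a methyl- or methoxy-bearing ring for the 3,5-difluorophenyl ring, and both were modest; no measured pair here adds a single fluoro to an aromatic carbon that already carries two, so the size of a further gain is not established. Compound 4 is therefore expected to land near compound 3, with a step of a 1.3-fold lower number from compound 3 to compound 4 (0.10 log units; within the scatter) that is estimated to stay within or only slightly beyond the scatter. For compound 4 the estimated value is 150 nM, in a range from 60 nM to 450 nM.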

Compound 4, half-maximal inhibitory concentration: 6960 nM
Beside the measured number, compound 4's estimate is 46-fold (1.67 log units) below it, and the stated range ends below it.
By their numbers in this assay, from the lowest: compound 3; then compounds 1 and 2 (each within the scatter of the next); then compound 4.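

In this assay, among these compounds, a single added fluoro on the aromatic carbon ortho to two fluoro groups and para to a large group gives the largest step (a 37-fold higher number from compound 3 to compound 4 (1.56 log units; beyond the scatter)), whereas the ring exchanges among the earlier compounds gave only modest steps, so this carbon tolerates even one extra heavy atom poorly. The 3,4,5-trifluorophenyl ring does not merely give back what the 3,5-difluorophenyl ring gained, as it also ends up on the weaker side of both the 3-methoxyphenyl ring (a 6.2-fold higher number from compound 2 to compound 4 (0.79 log units; beyond the scatter)) and the 3-methylphenyl ring (a 6.3-fold higher number from compound 1 to compound 4 (0.80 log units; beyond the scatter)). Nothing available here accounts for why one fluoro has so large an effect at this carbon.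

The compounds shown leave open whether the loss belongs to fluoro itself or would also follow from another group on this carbon, such as a hydroxyl, a methoxy or an amine. They also leave open what a ring carrying fluoro on this carbon alone, with neither of the other two fluoro groups, would give.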